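The compounds below may be only part of what the source reports. "The series", "measured", "known", "first", "only" and "open" are said of these compounds alone.

Measured compounds in the series:
compound 1 `CCCCc1cnc(C(CC)Cc2ccc(-c3ccccc3C(=O)O)cc2)[nH]1`, 340 nM
compound 2 `O=C(O)c1ccccc1-c1ccc(CCc2ncc(CC3CCC3)[nH]2)cc1`, 7.1 nM
compound 3 `N#Cc1ccccc1Cc1cnc(CCc2ccc(-c3ccccc3C(=O)O)cc2)[nH]1`, 642 nM

In an in vitro functional assay on cells for agonist activity at Bombesin receptor subtype-3 (Mus musculus), read by luminescence and calcium flux (a higher number here means that more compound is needed for the effect, a lower number that less compound is needed), compound 1 stands second highest of the three numbers; compound 3 sits within the scatter of it, while compound 2 lies well below both. Among the compounds with values here, the only single-place step measured, a 90-fold higher number from compound 2 to compound 3 (1.96 log units; beyond the scatter), concerns the group on the imidazole side chain and does not touch the linker.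

Compound 4 `CCCCc1cnc(C(C)Cc2ccc(-c3ccccc3C(=O)O)cc2)[nH]1` differs from compound 1 by hydrogen in place of methyl on a saturated chain carbon, two bonds along the chain from an aromatic carbon. Within the data shown here, no measured pair isolates this branch change; compound 2 and compound 3 both carry an unbranched linker but also differ elsewhere, so they give no clean reading. A step within or near the scatter, if anything toward a lower number, is expected: a 1.5-fold lower number from compound 1 to compound 4 (0.19 log units; within the scatter). Compound 4 is therefore estimated at 220 nM, range 70 nM to 700 nM.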

Compound 4, half-maximal effective concentration: 184 nM
Estimate against measurement, compound 4: 1.2-fold (0.08 log units) above; the range from low to high includes it.
By their numbers in this assay, from the lowest: compound 2; then compounds 4, 1 and 3 (each within the scatter of the next, the first and the last beyond it).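

Within the data shown here, the pair gives the first isolated reading at this position: hydrogen in place of methyl on this saturated chain carbon, the same difference as ethyl to methyl, gives a 1.8-fold lower number from compound 1 to compound 4 (0.27 log units; within the scatter) in this assay. This change in the branch therefore stays within the scatter with the rest of the structure held constant. Nothing available bears on the reason for this result.

Open, going by these compounds, is whether a hydroxyl or a longer chain on this carbon would give a step beyond the scatter. Also open, on these data alone, is whether the step reads the same with cyclobutyl on the side chain.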